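Series notes: trifluoromethyl in place of the chain

The source may report more compounds than this note shows. Statements on the series, on what has been measured and on what is new or still open speak of the compounds shown alone.

Going by the values given here, compound 2 `Oc1nc2nonc2nc1Nc1ccc(OCCCC(F)(F)F)c(F)c1` gives 4200 nM in an assay on mitochondria from L6 cells (Rattus norvegicus) for activation, with a stated time of 90 min (on this read-out lower numbers stand for an effect already at smaller amounts and higher numbers for an effect only at larger amounts of compound), the lowest of the two numbers so far; compound 1 `Oc1nc2nonc2nc1Nc1ccc(OCC(F)(F)F)c(F)c1` gives 10400 nM. Among the compounds with values here, the only step between measured compounds, a 2.5-fold lower number from compound 1 to compound 2 (0.39 log units; beyond the scatter), came from 3,3,3-trifluoropropyl in place of trifluoromethyl on a saturated chain carbon bound to an oxygen on an aromatic ring, so the longer chain gave the lower number. Compound 3 `Oc1nc2nonc2nc1Nc1ccc(C(F)(F)F)c(F)c1` goes the other way: trifluoromethyl in place of 4,4,4-trifluorobutoxy on an aromatic carbon. This removes the chain and the oxygen altogether and leaves a shorter group than in compound 1, so the lone step bears on it in reverse. A higher number than for compound 2 is expected, about the size of that one step or somewhat more. Within the data shown here, no compound without the oxygen has been measured, so the range is kept wide. Compound 3 is estimated at 15000 nM, range 5000 nM to 45000 nM. The expected step is a 3.6-fold higher number from compound 2 to compound 3 (0.55 log units; beyond the scatter).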

Compound 3, half-maximal effective concentration: 11600 nM
Beside the measured number, compound 3's estimate is 1.3-fold (0.11 log units) above it; measured number inside the range.
By their numbers in this assay, from the lowest: compound 2; then compounds 1 and 3 (each within the scatter of the next).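

In this assay, trifluoromethyl in place of 2,2,2-trifluoroethoxy gives a 1.1-fold higher number from compound 1 to compound 3 (0.05 log units; within the scatter) and so leaves compound 1 and compound 3 indistinguishable on this aromatic carbon. Trifluoromethyl in place of 4,4,4-trifluorobutoxy gives a 2.8-fold higher number from compound 2 to compound 3 (0.44 log units; beyond the scatter); among these three compounds, the lower number therefore goes with the 4,4,4-trifluorobutoxy chain of compound 2, and the ether oxygen alone does not account for it, since compound 1 carries that oxygen too. No supporting measurement is available to explain either step.

From the compounds shown here alone, it remains open whether a longer chain ending in trifluoromethyl would continue the trend or whether a plain butoxy chain without fluorine would match compound 2. The compounds shown also leave open how an amine or a carboxylic acid at the end of the chain would read out at this position.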